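Half-life: ester variation on a bicyclic diol core

The compounds below may be only part of what the source reports. "The series", "measured", "known", "first", "only" and "open" are said of these compounds alone.

Measured compounds:
- compound 1, `CC(=O)Oc1ccccc1C(=O)O[C@H]1CO[C@H]2[C@@H]1OC[C@H]2OC(=O)c1ccccc1O`, 0.0825 h
- compound 2, `CC(=O)Oc1ccccc1C(=O)O[C@H]1CO[C@H]2[C@@H]1OC[C@H]2OC(=O)c1snnc1C`, 0.0642 h
- compound 3, `CC(=O)Oc1ccccc1C(=O)O[C@H]1CO[C@H]2[C@@H]1OC[C@H]2OC(C)=O`, 0.0608 h

The three compounds share one core and differ only in the acyl group on one of its two ester oxygens. All were run in an ADME assay on a cell-free system (plasma, Homo sapiens) for metabolic stability, with Plasma (Rattus norvegicus) as the target, read by HPLC, at pH 7.4; on this read-out higher numbers stand for a longer-lived compound and lower numbers for a shorter-lived compound. Compound 3 is not separated from either neighbour: the step of a 1.4-fold lower number from compound 1 to compound 3 (0.13 log units; within the scatter) and the step of a 1.1-fold lower number from compound 2 to compound 3 (0.02 log units; within the scatter) are both within the scatter, as is a 1.3-fold lower number from compound 1 to compound 2 (0.11 log units; within the scatter). On the numbers shown, the 2-hydroxyphenyl, 4-methyl-1,2,3-thiadiazol-5-yl and methyl variants are indistinguishable in this assay.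

Compound 4, `CC(=O)Oc1ccccc1C(=O)O[C@H]1CO[C@H]2[C@@H]1OC[C@H]2OC(=O)c1ccccc1C`, is not yet measured. Its difference from compound 3 is 2-methylphenyl in place of methyl on a carbonyl carbon. Among the compounds with values here, the closest precedent is the step between compound 1 and compound 3, where an aromatic acyl group stands against the acetyl, and that step was within scatter; the thiadiazolyl variant of compound 2 tells the same story. No measured step therefore gives reason to expect compound 4 to move beyond the scatter in this assay, in either direction.

Compound 4 is accordingly estimated at 0.072 h, with a range of 0.038 h to 0.14 h, which corresponds to an expected step of a 1.2-fold higher number from compound 3 to compound 4 (0.07 log units; within the scatter).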

Compound 4, half-life: 0.035 h
Beside the measured number, compound 4's estimate is 2.1-fold (0.31 log units) above it; measured number below the stated range.
By their numbers in this assay, from the lowest: compounds 4, 3, 2 and 1 (each within the scatter of the next, the first and the last beyond it).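

In this assay the 2-methylphenyl group on a carbonyl carbon does not separate from either the methyl group (a 1.7-fold lower number from compound 3 to compound 4 (0.24 log units; within the scatter)) or the 4-methyl-1,2,3-thiadiazol-5-yl group (a 1.8-fold lower number from compound 2 to compound 4 (0.26 log units; within the scatter)), so all the acyl exchanges at this place that involve compound 4 with a change of the whole group remain unresolved, now including one that brings in a ring of carbon only. Within the data shown here, the new information lies in a smaller change on the aromatic ring: methyl in place of hydroxy on an aromatic carbon gives the first step beyond the scatter, though a modest one (a 2.4-fold lower number from compound 1 to compound 4 (0.37 log units; beyond the scatter)). Nothing measured here accounts for that step.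

From the compounds shown here alone, whether the separation belongs to the loss of hydroxy or to the arrival of methyl stays open, as a single pair cannot divide the two, and an unsubstituted phenyl, a methoxy or an amino group on that aromatic carbon would bear on this. Equally open, going by these compounds, is whether a longer alkyl chain in place of methyl on the carbonyl carbon would stay within the scatter of compound 3.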